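Swapping the anilino link of compound 1 for a phenoxy link

The source may report more compounds than this note shows. Statements on the series, on what has been measured and on what is new or still open speak of the compounds shown alone.

Measured compounds:
compound 1, `Cc1ccc(Nc2ncc3c(n2)N(C)C(=O)N(c2cc(NC(=O)c4cccc(C(F)(F)F)c4)ccc2C)C3)cc1C`: 17 nM
compound 2, `Cc1ccc(Nc2ncc3c(n2)N(C)C(=O)N(c2cc(NC(=O)c4cccc(C(F)(F)F)c4)ccc2C)C3)cc1`: 18 nM

In a functional assay on K562 cells (Homo sapiens) for antiproliferative activity, read by CellTiter-Glo and CCK-8 assay, with a stated time of 72 h (a lower number here means a stronger inhibitor of growth, a higher number a weaker inhibitor of growth), compound 1 gives 17 nM, at one end of the two numbers, but the step of a 1.1-fold higher number from compound 1 to compound 2 (0.02 log units; within the scatter) is within the scatter, so compound 1 and compound 2 cannot be told apart. Compound 3, `Cc1ccc(Oc2ncc3c(n2)N(C)C(=O)N(c2cc(NC(=O)c4cccc(C(F)(F)F)c4)ccc2C)C3)cc1N`, differs from compound 1 in one place: 3-amino-4-methylphenoxy in place of (3,4-dimethylphenyl)amino on an aromatic carbon. Going by the values given here, the only measured step exchanges a methyl for a hydrogen on an aromatic carbon and does not touch the linking group, so no measured step speaks to this change. A step beyond the scatter toward a higher number is expected, a 12-fold higher number from compound 1 to compound 3 (1.07 log units; beyond the scatter). Compound 3 is estimated at 200 nM, between 40 nM and 1200 nM.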

Compound 3, concentration for 50% growth inhibition: 13 nM
Compound 3: middle estimate off by 15-fold (1.19 log units), on the high side; measured number below the stated range.
By their numbers in this assay, from the lowest: compounds 3, 1 and 2 (each within the scatter of the next).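

In this assay, this position on the shared core accepts a change of both link and ring substituent: a 1.3-fold lower number from compound 1 to compound 3 (0.12 log units; within the scatter) and a 1.4-fold lower number from compound 2 to compound 3 (0.14 log units; within the scatter) both stay within the scatter. Going by these compounds alone, until now only a single methyl on that ring had been varied, so 3-amino-4-methylphenoxy is the first evidence that the nitrogen link can be replaced by oxygen with growth inhibition retained. Nothing available explains why the numbers hold.

On these data alone, the oxygen link and the ring amine enter together, so their separate contributions remain open. As far as these compounds go, how a carboxylic acid on that ring would fare is also open.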